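Compound 2 and a 1H-1,2,3-triazol-4-yl Swap

The source may report more compounds than this note shows. Statements on the series, on what has been measured and on what is new or still open speak of the compounds shown alone.

Of the compounds shown here, three have so far been measured in a physicochemical assay for lipophilicity, read by HPLC, measured as chromatographic lipophilicity, at pH 7.4; a lower number here means a more polar compound, a higher number a more lipophilic compound. Compound 1 (`CC(C)(C)C(=O)N1N=CCC1c1cc(F)cc(F)c1`) gives 6.3, and compound 3 (`CC(C)(C)C(=O)N1N=CCC1c1cccnc1`) gives 3.2. Compound 2 (`O=C(c1cn[nH]c1)N1CCC(C(=O)N2N=CCC2c2ccccc2)CC1`) gives 2.1, the lowest of the three and beyond the scatter from both of the others.

Compound 4 (`O=C(c1c[nH]nn1)N1CCC(C(=O)N2N=CCC2c2ccccc2)CC1`) has not yet been measured. It differs from compound 2 in a single place: 1H-1,2,3-triazol-4-yl in place of 1H-pyrazol-4-yl on a carbonyl carbon. Put simply, 1H-1,2,3-triazol-4-yl stands in place of 1H-pyrazol-4-yl on a carbonyl carbon, and the rest of the structure stays the same. Within the data shown here, no measured pair shows this exchange, so its effect in this assay can only be judged from the structures. The natural starting point is compound 2 at 2.1.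

A small step towards lower numbers is expected, a number 0.30 log units lower from compound 2 to compound 4 (within the scatter). Compound 4 is therefore estimated at 1.8, with an expected range from 1.2 to 2.3.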

Compound 4, distribution coefficient: 2
Beside the measured number, compound 4's estimate is 0.20 log units below it; low and high end bracket the measured number.
By their numbers in this assay, from the lowest: compounds 4 and 2 (each within the scatter of the next); then compound 3; then compound 1.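

In this assay, placing 1H-1,2,3-triazol-4-yl where 1H-pyrazol-4-yl stood on a carbonyl carbon gives a number 0.10 log units lower from compound 2 to compound 4 (within the scatter), so this single pair does not separate the two rings at this position. The entering ring has 3 hetero atoms and 2 hydrogen-bond acceptors, whereas the leaving ring has 2 hetero atoms and 1 hydrogen-bond acceptor, yet that difference in counts brings no step beyond the scatter here. Nothing measured in this set explains the result.

Among these compounds, this exchange is seen on only one pair, so whether it behaves in the same way on another core remains open. Also open, as far as these compounds go, is what this assay would read with a plain phenyl ring or a carboxylic acid-bearing ring on the same carbonyl carbon.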